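This account rests on a few compounds, and the source may have more. Where it says the series, first, only, none or still open, it means among the compounds named here.

Three compounds define the starting picture. Compound 1 `CCc1cnc(N2CCC(c3coc4c(N5CCc6cc(S(C)(=O)=O)ccc65)ncnc34)CC2)nc1` gives 41 nM in a functional assay on cells for agonist activity at Glucose-dependent insulinotropic receptor (Homo sapiens), read by a luciferase reporter, with a stated time of 4 h; a higher number here means that more compound is needed for the effect, a lower number that less compound is needed. Compound 2 `CS(=O)(=O)c1ccc2c(c1)CCN2c1ncnc2c(C3CCN(c4ncccn4)CC3)coc12` gives 512 nM. Compound 3 `CC(C)(C)OC(=O)N1CCC(c2coc3c(Nc4ccc(S(C)(=O)=O)cc4F)ncnc23)CC1`, built differently from the other two, gives 129 nM. Compound 2 therefore holds the highest number of the three: compound 3 sits nearest to it, and compound 1 sits furthest away.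

For the measured compounds named here, the only step between two compounds that differ in one place runs from compound 1 to compound 2, where a 12-fold higher number from compound 1 to compound 2 (1.10 log units; beyond the scatter) went with a hydrogen in place of an ethyl on an aromatic carbon. Removing the group at that carbon thus cost a great deal.

Compound 4 `CS(=O)(=O)c1ccc2c(c1)CCN2c1ncnc2c(C3CCN(c4ncc(Cl)cn4)CC3)coc12` returns to the same aromatic carbon and differs from compound 2 by chloro in place of hydrogen on an aromatic carbon, placed two atoms from the ring nitrogen and para to a large group. Because a 12-fold higher number from compound 1 to compound 2 (1.10 log units; beyond the scatter) was large, restoring a substituent at that carbon is expected to push the number back down, though whether chloro matches ethyl is not known from these compounds alone. Compound 4 is therefore expected at about 70 nM, within a range of 20 nM to 250 nM, which would be an expected step of a 7.3-fold lower number from compound 2 to compound 4 (0.86 log units; beyond the scatter).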

Compound 4, half-maximal effective concentration: 42 nM
Compound 4: the middle estimate sits 1.7-fold (0.22 log units) above what was measured, within the range that was stated.
By their numbers in this assay, from the lowest: compounds 1 and 4 (each within the scatter of the next); then compound 3; then compound 2.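

The step of a 12-fold lower number from compound 2 to compound 4 (1.09 log units; beyond the scatter) shows that the gain at this carbon, two atoms from the ring nitrogen, is not tied to ethyl, since a single chlorine atom in place of hydrogen also goes with a large fall in the number needed for the effect. The step of a 1.0-fold higher number from compound 1 to compound 4 (0.01 log units; within the scatter) lies within the scatter, so in this assay the 5-chloropyrimidin-2-yl and ethyl-bearing versions cannot be told apart, and among these three compounds only the unsubstituted pyrimidin-2-yl version, compound 2, stands apart from the others. Nothing measured here explains why hydrogen at this carbon differs so much from either group.

These three compounds cannot show whether other groups at this carbon, such as methoxy, nitrile, an amine or a longer chain like propyl, would serve as well as chloro and ethyl, or whether some would fail. From the compounds shown here alone, it also remains open whether the same change would give a similar step on a differently built compound such as compound 3, which carries a tert-butyl carbamate at the ring nitrogen in place of any pyrimidine.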